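The source may hold more compounds than are shown below. What is called first, only, known or untested is meant among the compounds shown, and "the series" means these compounds.

Three compounds share one core and differ only in a short chain carried on that core. In an assay on isolated protein for inhibition of protein kinase C epsilon type (Homo sapiens), read by coupled enzyme assay (on this read-out higher numbers stand for weaker inhibition and lower numbers for stronger inhibition), compound 1 `C[C@H](O)Cc1cc(-c2ccnc3[nH]nc(C(F)(F)F)c23)cc(C2(C#N)CC2)c1` gives 51 nM, compound 2 `CC(C)C(O)Cc1cc(-c2ccnc3[nH]nc(C(F)(F)F)c23)cc(C2(C#N)CC2)c1` gives 215 nM, and compound 3 `COCCc1cc(-c2ccnc3[nH]nc(C(F)(F)F)c23)cc(C2(C#N)CC2)c1` gives 145 nM. Compound 3 thus stands second highest of the three: the step of a 2.8-fold higher number from compound 1 to compound 3 (0.45 log units; beyond the scatter) is a weakening beyond the scatter, whereas the step of a 1.5-fold lower number from compound 2 to compound 3 (0.17 log units; within the scatter) is too small to count. Compound 4 `N#CC1(c2cc(CCF)cc(-c3ccnc4[nH]nc(C(F)(F)F)c34)c2)CC1` has not yet been measured. It differs from compound 3 by fluoro in place of methoxy on a saturated chain carbon, two bonds along the chain from an aromatic carbon. Within the data shown here, no measured step exchanges one chain end for another in just this way; the nearest guide is that replacing the 1-hydroxyethyl chain of compound 1 by the methoxymethyl chain of compound 3 cost a 2.8-fold higher number from compound 1 to compound 3 (0.45 log units; beyond the scatter), while the chains of compound 2 and compound 3 sit close together. A further small loss, or no change beyond the scatter, is therefore expected in this assay, an estimated step of a 1.5-fold higher number from compound 3 to compound 4 (0.18 log units; within the scatter). Compound 4 is estimated at 220 nM, with a range from 70 nM to 700 nM.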

Compound 4, inhibition constant: 90 nM
Beside the measured number, compound 4's estimate is 2.4-fold (0.39 log units) above it; the range from low to high includes it.
By their numbers in this assay, from the lowest: compounds 1, 4, 3 and 2 (each within the scatter of the next, the first and the last beyond it).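

In this assay, 2-fluoroethyl and 2-methoxyethyl cannot be told apart at this position, since a 1.6-fold lower number from compound 3 to compound 4 (0.21 log units; within the scatter) shows that losing the oxygen makes no readable difference. The fluoro chain, which has no hydrogen-bond donor, also stays close to the 1-hydroxyethyl chain, with a 1.8-fold higher number from compound 1 to compound 4 (0.25 log units; within the scatter), so a hydroxy group is not needed for a number in this range, while a 2.4-fold lower number from compound 2 to compound 4 (0.38 log units; beyond the scatter) shows that the 1-hydroxy-2-methylpropyl chain, which does carry one, sits clearly higher. Nothing measured here gives a reason for these steps.

Still open, as far as these compounds go, is how a plain ethyl chain, with neither oxygen nor fluorine at its end, would read, which would show whether the fluoro contributes at all. An amine or a carboxylic acid at the chain end, or a longer chain, also remains untested among the compounds shown.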